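Phenyl for sec-butyl on a weakly inhibiting core

This account rests on a few compounds, and the source may have more. Where it says the series, first, only, none or still open, it means among the compounds named here.

Compound 1 `CCC(C)C1NC(=O)N(C2CCCC2)C1=O`: > 100000 nM in a functional assay on HEp-2 cells (Homo sapiens) for inhibition; on this read-out higher numbers stand for weaker inhibition and lower numbers for stronger inhibition
Compound 2 `CCC(C)C1NC(=O)N(Cc2ccccc2)C1=O`: in this assay compound 2 gives 47000 nM.

For compound 1 the value is not a number but a limit of the assay, the point where (the limit of > 100000 nM in this assay, at which 1 of the 2 values shown sits). Compound 2 gives a measurable number in this assay. Compound 3 `O=C1NC(c2ccccc2)C(=O)N1C1CCCC1` is not yet measured; it differs from compound 1 by phenyl in place of sec-butyl on a saturated ring carbon. For the measured compounds named here, no measured pair shows this change, so in this assay a step of the size a number no higher from compound 1 to compound 3 (the limit leaves the size open) is expected, no larger than the scatter, and a limit may again be reported. Compound 3 is expected near 100000 nM, between 30000 nM and 300000 nM.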

Compound 3, half-maximal inhibitory concentration: > 100000 nM
Compound 3 ended at the assay's limit; the forecaster's own chance of this, stated with the estimate: 60%; the middle value lies on the limit itself.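

Compound 1 and compound 3 both give a limit rather than a number, so no step between them can be read: the limit of > 100000 nM in this assay, at which 2 of the 3 values shown sit.

From the compounds shown here alone, whether phenyl in place of sec-butyl on a saturated ring carbon changes inhibition at all remains open.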